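Aryl swap on compound 3: ethoxyphenyl to dimethylphenyl

The source may report more compounds than this note shows. Statements on the series, on what has been measured and on what is new or still open speak of the compounds shown alone.

Compound 3 `CCOc1ccccc1-n1nncc1CN1C(=O)C2(C(C#N)=C(N)Oc3c(N)cc4nc5ccccc5nc4c32)c2ccccc21` carries a 2-ethoxyphenyl on an aromatic nitrogen. In an ADME assay on HUVEC cells (Homo sapiens) for antiproliferative activity, read by MTT assay, with a stated time of 48 h (a higher number here means a weaker inhibitor, a lower number a stronger inhibitor), compound 3 gives > 50000 nM, which is a limit of the assay and not a number. Compound 1 `N#CC1=C(N)Oc2c(N)cc3nc4ccccc4nc3c2C12C(=O)N(Cc1cnnn1-c1cccc(Br)c1)c1ccccc12`, with 3-bromophenyl in that place, gives > 50000 nM in this assay, again a limit. Compound 2 `N#CC1=C(N)Oc2c(N)cc3nc4ccccc4nc3c2C12C(=O)N(Cc1cnnn1-c1ccccc1Br)c1ccccc12`, with 2-bromophenyl, gives 34200 nM in this assay. The step of an at least 1.4-fold lower number from compound 1 to compound 2 (0.16 log units; that floor lies within the scatter) and the step of an at least 1.4-fold higher number from compound 2 to compound 3 (0.16 log units; that floor lies within the scatter) are floors only, and the limit of > 50000 nM in this assay, at which 2 of the 3 values shown sit, covers two of the three values, so compound 3 stands at the reporting limit with no order readable against compound 1.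

Compound 4 `Cc1ccc(C)c(-n2nncc2CN2C(=O)C3(C(C#N)=C(N)Oc4c(N)cc5nc6ccccc6nc5c43)c3ccccc32)c1` differs from compound 3 by 2,5-dimethylphenyl in place of 2-ethoxyphenyl on an aromatic nitrogen. Going by the values given here, no measured step exchanges ethoxy for methyl or adds a second substituent on this ring. Among the compounds with values here, the steps that bear on it are an at least 1.4-fold higher number from compound 2 to compound 3 (0.16 log units; that floor lies within the scatter), a floor within the scatter, and an at least 1.4-fold lower number from compound 1 to compound 2 (0.16 log units; that floor lies within the scatter), also a floor within the scatter. Neither aryl variant moved this assay beyond the scatter, so no step beyond the scatter is expected here. The expected step is a step that the limit leaves unreadable from compound 3 to compound 4. Compound 4 is therefore estimated at 60000 nM, in a range from 25000 nM to 150000 nM, most likely reported only as a limit.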

Compound 4, half-maximal inhibitory concentration: > 50000 nM
Compound 4: only a limit was reported; the forecaster's own chance of this, stated with the estimate: 65%; the middle value does not contradict the limit.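

Exchanging 2-ethoxyphenyl for 2,5-dimethylphenyl on this aromatic nitrogen removes the oxygen from the aryl group and adds a second substituent on the ring, yet in this assay neither change gives a reading that separates compound 4 from compound 3; the steps from compound 3 and from compound 1 to compound 4 cannot be read, as both ends of each are limits. The one readable step is an at least 1.4-fold higher number from compound 2 to compound 4 (0.16 log units; that floor lies within the scatter), so compound 4 is not shown to differ from compound 2 beyond the scatter. This aryl position has now taken bromo, ethoxy and dimethyl patterns without a value clear of the reporting limit, and compound 2 alone reads as a number, a pattern confined to these compounds: the limit of > 50000 nM in this assay, at which 3 of the 4 values shown sit.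

On these data alone, whether an aryl ring carrying an amine or a carboxylic acid, or a benzyl group in place of the aryl on this nitrogen, would give a value well clear of that limit stays open. As far as these compounds go, the order among compound 1, compound 3 and compound 4 also stays open, and so does any effect of these aryl changes in a range this assay can report.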